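A few compounds are considered here, and "the series" means these few. Any claim that something is new, unique, unknown or untested is made for them only; others in the source may bear on it.

Measured compounds:
Compound 1 `Nc1c(Br)cc(Br)cc1/C=C(\C(=O)c1ccc(Br)cc1)S(=O)(=O)c1ccc(Br)cc1` gives 25000 nM.
Compound 2 `O=C(O)c1ccc(C(=O)/C(=C\N2CCN(Cc3ccccc3)C([N+](=O)[O-])C2)SCc2ccc(F)cc2)cc1` gives 1000 nM.
Compound 3 `Nc1c(Br)cc(Br)cc1/C=C(/Sc1ccc(Br)cc1)C(=O)c1ccc(Br)cc1` gives only a limit, > 100000 nM.

In a functional assay on DU-145 cells (Homo sapiens) for inhibition, read by trypan blue exclusion, with a stated time of 96 h (on this read-out higher numbers stand for weaker inhibition of growth and lower numbers for stronger inhibition of growth), compound 1 stands at 25000 nM, the higher of the two plain numbers; compound 2, built on a different core, gives the lower number. Compound 3 reaches only the limit (the limit of > 100000 nM in this assay, at which 1 of the 3 values shown sits). Among the compounds with values here, the one measured step, an at least 4.0-fold higher number from compound 1 to compound 3 (0.60 log units; beyond the scatter), changes the group on the sulfur-bearing chain carbon, not the aromatic ring that is swapped in compound 4 `O=C(/C(=C\c1ccc(F)cc1Cl)S(=O)(=O)c1ccc(Br)cc1)c1ccc(Br)cc1`. That change is 2-chloro-4-fluorophenyl in place of 2-amino-3,5-dibromophenyl on a double-bonded chain carbon bound to a double-bonded chain carbon. Within the data shown here, no measured step touches this position, and the only step that exists acts elsewhere on the shared core, so it offers no guide to direction. The expectation is therefore a step of no change at the digits printed from compound 1 to compound 4 (within the scatter), that is, no change beyond the usual scatter. Compound 4 is estimated to give 25000 nM, with a likely range from 8000 nM to 80000 nM.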

Compound 4, concentration for 50% growth inhibition: 50000 nM
Beside the measured number, compound 4's estimate is 2.0-fold (0.30 log units) below it; measured number inside the range.
By their numbers in this assay, from the lowest: compound 2; then compounds 1 and 4 (each within the scatter of the next). At a limit, above all of these: compound 3.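

In this assay, the swap at this position gives a 2.0-fold higher number from compound 1 to compound 4 (0.30 log units; within the scatter). Within the data shown here, this is the first reading for the aromatic ring on a double-bonded chain carbon bound to a double-bonded chain carbon, and it shows that 2-amino-3,5-dibromophenyl can give way to 2-chloro-4-fluorophenyl with no change that stands out from the scatter, even though the entering group has no hydrogen-bond donors and the leaving group has one. Nothing measured here gives a reason for this outcome.

Because the amine and both bromines leave together, the compounds shown cannot tell whether each of these groups alone would make no difference. They also leave open what a quite different group on this ring, such as a carboxylic acid or a methoxy group, would do to growth inhibition.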